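A few compounds are considered here, and "the series" means these few. Any claim that something is new, unique, unknown or untested is made for them only; others in the source may bear on it.

Of the compounds shown here, three have been measured in an assay on RKO cells for inhibition of ubiquitin carboxyl-terminal hydrolase 7 (Homo sapiens), read by a luciferase reporter, with a stated time of 18 h; on this read-out lower numbers stand for an effect already at smaller amounts and higher numbers for an effect only at larger amounts of compound. Compound 1 `Cc1cc(Cl)cc(-c2ccnc3cc(CN4C(=O)CCC4=O)sc23)c1CN1CCNC[C@@H]1C` gives 280 nM in this assay. Compound 2 `Cc1cc(Cl)cc(-c2ccnc3cc(CN4C(=O)C5C(C4=O)C5(C)C)sc23)c1O[C@@H]1CCNC[C@@H]1C` gives 65 nM in this assay. Compound 3 `Cc1cc(Cl)cc(-c2ccnc3cc(CN4C(=O)CCC4=O)sc23)c1OC1CCNCC1` gives 400 nM in this assay, the highest of the three numbers, though its distance to compound 1 is within the scatter and only its distance to compound 2 lies beyond it. Going by the values given here, the one single-point step among them, a 1.4-fold higher number from compound 1 to compound 3 (0.15 log units; within the scatter), changes nothing that can be trusted.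

Compound 4 `Cc1cc(Cl)cc(-c2ccnc3cc(CN4C(=O)CCC4=O)sc23)c1O[C@@H]1CCNC[C@@H]1C` is the next candidate. It differs from compound 3 in one place: methyl in place of hydrogen on a saturated ring carbon. Among the compounds with values here, no measured pair isolates this change on an otherwise identical scaffold. Compound 2 carries the same methyl on the saturated ring, but it also carries a different imide, so its gap to compound 3 cannot be assigned to the methyl alone; it only shows that a compound bearing this methyl can sit well below compound 3. Because the pairing of compound 2 at 65 nM with compound 3 at 400 nM is the nearest guide, a moderate downward step is expected for compound 4, a 2.2-fold lower number from compound 3 to compound 4 (0.35 log units; beyond the scatter), while the lack of a clean comparison keeps the range wide. Compound 4 is therefore estimated at 180 nM in this assay, between 70 nM and 450 nM.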

Compound 4, half-maximal effective concentration: 150 nM
For compound 4 the middle estimate is 1.2-fold (0.08 log units) above the measured one, and the stated range covers the measured number.
By their numbers in this assay, from the lowest: compound 2; then compounds 4, 1 and 3 (each within the scatter of the next, the first and the last beyond it).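

In this assay the methyl on the saturated ring carbon now has a clean pair of its own: a 2.7-fold lower number from compound 3 to compound 4 (0.43 log units; beyond the scatter), a modest step that lies beyond the scatter and shows that (3-methylpiperidin-4-yl)oxy in place of (piperidin-4-yl)oxy lowers the number on an otherwise unchanged compound. With that methyl held constant, the imide can also be read on its own, and a 2.3-fold higher number from compound 2 to compound 4 (0.36 log units; beyond the scatter) shows that the group with the three-membered carbon ring, as carried by compound 2, goes with the lower number. The link on the aromatic carbon gives no such reading, since a 1.9-fold lower number from compound 1 to compound 4 (0.27 log units; within the scatter) stays within the scatter, so (3-methylpiperidin-4-yl)oxy and (2-methylpiperazin-1-yl)methyl cannot be told apart in this comparison.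

Nothing available speaks to the reason for any of these steps. The compounds shown leave open whether an ethyl or a hydroxyl on the same saturated ring carbon would take the number further in either direction, and how the methyl would read in the opposite stereo arrangement.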